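Swapping Methoxy for Trifluoromethyl on an Aryl Alkyne

A few compounds are considered here, and "the series" means these few. Any claim that something is new, unique, unknown or untested is made for them only; others in the source may bear on it.

Of the compounds shown here, two have so far been tested in an assay on CHO cells for displacement of a labelled ligand from prostaglandin D2 receptor 2 (Homo sapiens), read by scintillation counting; on this read-out lower numbers stand for stronger inhibition and higher numbers for weaker inhibition. Compound 1 `CC1(O)c2ccc(C#Cc3cc(Cl)ccc3OCC(=O)O)cc2S(=O)(=O)C1(C)C` gives 28 nM, while compound 2 `COc1ccccc1C#Cc1cc(Cl)ccc1OCC(=O)O` gives 190 nM. Compound 2 is thus the weaker binder of the pair, and its gap to compound 1 lies beyond the usual scatter of repeated measurements.

Compound 3 `O=C(O)COc1ccc(Cl)cc1C#Cc1ccccc1C(F)(F)F` has not yet been measured. It differs from compound 2 in a single place: trifluoromethyl in place of methoxy on an aromatic carbon. The exchange sits on an aromatic carbon of a six-membered aromatic ring of carbon only, ortho to a large group.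

Going by the values given here, no measured pair in this set shows what this exchange does, so any expectation rests on the two values above alone. For compound 3 the step of a 1.6-fold lower number from compound 2 to compound 3 (0.20 log units; within the scatter) is expected to be modest, if anything slightly towards stronger inhibition, and possibly not beyond the scatter. Compound 3 is therefore estimated at 120 nM, with a likely range from 40 nM to 400 nM.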

Compound 3, inhibition constant: 24 nM
Beside the measured number, compound 3's estimate is 5.0-fold (0.70 log units) above it; the measured number lies below the stated range.
By their numbers in this assay, from the lowest: compounds 3 and 1 (each within the scatter of the next); then compound 2.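

In this assay, going by these compounds alone, trifluoromethyl in place of methoxy on this aromatic carbon, ortho to a large group, gives a 7.9-fold lower number from compound 2 to compound 3 (0.90 log units; beyond the scatter) and is the first single-place change measured in this set. It shows that binding here depends on which group this carbon carries, since one exchange at this one place moves the number beyond the scatter. No measurement shown here accounts for the change.

On these data alone, only methoxy and trifluoromethyl can be compared at this position, so it stays open how a methyl group, a chlorine atom or a nitrile would fare there. As far as these compounds go, it also stays open whether the same exchange would give a similar step on another carbon of this ring, or on the core of compound 1.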